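The source may report more compounds than this note shows. Statements on the series, on what has been measured and on what is new or still open speak of the compounds shown alone.

Measured in a functional assay on HCT-116 cells (Homo sapiens) for cytotoxicity, read by sulforhodamine B assay, with a stated time of 24 h; a higher number here means a weaker inhibitor, a lower number a stronger inhibitor:
- compound 1 `N=c1oc2ccccc2cc1C(=O)N/N=C1\C(=O)Nc2ccc(S(=O)(=O)N3CCOCC3)cc21`: 6750 nM
- compound 2 `O=C1Nc2ccc(S(=O)(=O)N3CCOCC3)cc2/C1=N/c1ccc(O)cc1`: 27300 nM
- compound 3 `O=C1Nc2ccc(S(=O)(=O)N3CCOCC3)cc2/C1=N/c1cccc(C(F)(F)F)c1`: 15900 nM

With 15900 nM, compound 3 has the second highest of these three numbers. Its gap to compound 2 is small: a 1.7-fold lower number from compound 2 to compound 3 (0.23 log units; within the scatter). Compound 1 has a lower number, 6750 nM, and that gap lies beyond the scatter.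

Compound 4 `CC(=O)N/N=C1\C(=O)Nc2ccc(S(=O)(=O)N3CCOCC3)cc21` carries acetamido in place of 3-(trifluoromethyl)phenyl on a double-bonded nitrogen. Among the compounds with values here, the only measured step, a 1.7-fold lower number from compound 2 to compound 3 (0.23 log units; within the scatter), swaps one substituted phenyl for another, so it says little directly about losing the phenyl ring. It does show that this position tolerated a change without a shift beyond the scatter. Compound 1, at 6750 nM, also has a carbonyl-bearing group on that nitrogen, which tilts the expectation slightly towards a lower number.

The expected step is small, a 1.2-fold lower number from compound 3 to compound 4 (0.09 log units; within the scatter), and is not expected to exceed the scatter. The estimate for compound 4 is 13000 nM, with an expected range of 5000 nM to 35000 nM.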

Compound 4, half-maximal inhibitory concentration: 29000 nM
The estimate for compound 4 lay 2.2-fold (0.35 log units) below the measured number, and the stated range covers the measured number.
By their numbers in this assay, from the lowest: compound 1; then compounds 3, 2 and 4 (each within the scatter of the next).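

Taking the aromatic ring off this nitrogen altogether moves the number no further than the swap between phenyl groups did: a 1.8-fold higher number from compound 3 to compound 4 (0.26 log units; within the scatter), and a 1.1-fold higher number from compound 2 to compound 4 (0.03 log units; within the scatter). Among these compounds, then, the small acetamido group and the two substituted phenyl groups cannot be told apart, so a phenyl ring on the double-bonded nitrogen is not needed to keep the number in this range. The change that does register is on the carbonyl carbon, where one carbon atom replaces the group of 11 heavy atoms in compound 1: a 4.3-fold higher number from compound 1 to compound 4 (0.63 log units; beyond the scatter). No measurement available here accounts for either result. Going by these compounds, this rests on a single pair, so it stays open whether a plain phenyl or a longer alkyl chain on that carbonyl carbon would fall nearer compound 1 or compound 4.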